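Fluorohydroxyphenyl replaces methylsulfonylphenyl on the hydrazone

The source may report more compounds than this note shows. Statements on the series, on what has been measured and on what is new or still open speak of the compounds shown alone.

Compound 3 `Cn1c(=O)c(=O)n(C2CCCC2)c2nc(N/N=C/c3ccc(S(C)(=O)=O)cc3)ncc21` gives 26600 nM in a functional assay on PC-3 cells (Homo sapiens) for antiproliferative activity, read by MTT assay (on this read-out lower numbers stand for stronger inhibition and higher numbers for weaker inhibition), the lowest of the two numbers available; compound 2 `Cc1cccc(/C=N/Nc2ncc3c(n2)n(C2CCCC2)c(=O)c(=O)n3C)c1` gives 53600 nM, and a 2.0-fold lower number from compound 2 to compound 3 (0.30 log units; within the scatter). Compound 1 `Cn1c(=O)c(=O)n(C2CCCC2)c2nc(N/N=C/c3ccc(O)cc3)ncc21` returns only a limit, > 100000 nM (the limit of > 100000 nM in this assay, at which 1 of the 3 values shown sits). Compound 4 `Cn1c(=O)c(=O)n(C2CCCC2)c2nc(N/N=C/c3ccc(O)c(F)c3)ncc21` carries 3-fluoro-4-hydroxyphenyl in place of 4-(methylsulfonyl)phenyl on a carbon with a double bond to nitrogen. The step that bears on this is an at least 3.7-fold lower number from compound 1 to compound 3 (0.57 log units; beyond the scatter), which ran from the hydroxy-bearing compound to the methylsulfonyl-bearing one; compound 4 reverses that direction, while adding fluorine to the ring. A higher number is therefore expected, with a 3.0-fold higher number from compound 3 to compound 4 (0.48 log units; beyond the scatter), and a limit is a real possibility. Compound 4 is estimated at 80000 nM, within 30000 nM to 200000 nM.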

Compound 4, half-maximal inhibitory concentration: 85200 nM
Compound 4: the middle estimate sits 1.1-fold (0.03 log units) below what was measured; the measured number falls inside the stated range.
By their numbers in this assay, from the lowest: compounds 3, 2 and 4 (each within the scatter of the next, the first and the last beyond it). At a limit, above all of these: compound 1.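

In this assay the hydrazone position now gives a measured pair beyond the scatter, with a 3.2-fold higher number from compound 3 to compound 4 (0.51 log units; beyond the scatter), so 4-(methylsulfonyl)phenyl and 3-fluoro-4-hydroxyphenyl can be told apart here. With 3-fluoro-4-hydroxyphenyl in place of 3-methylphenyl on a carbon with a double bond to nitrogen there is a 1.6-fold higher number from compound 2 to compound 4 (0.20 log units; within the scatter) and the two groups cannot be told apart. Compound 1 stands at a limit, so the step of an at least 1.1-fold lower number from compound 1 to compound 4 (0.06 log units; that floor lies within the scatter) for fluoro in place of hydrogen on an aromatic carbon cannot be read: the limit of > 100000 nM in this assay, at which 1 of the 4 values shown sits.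

The compounds shown leave open whether the fluoro or the hydroxy carries the step from compound 3. They also leave open how a phenyl bearing an amine or a carboxylic acid would read in this place.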